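This account rests on a few compounds, and the source may have more. Where it says the series, first, only, none or still open, it means among the compounds named here.

Compound 1 (`CCCC(=O)CC/C=C/C=C/C#CC#C/C=C/COC(=O)CCl`) gives 19300 nM
Compound 2 (`CCCC(=O)CC/C=C/C=C/C#CC#C/C=C/C=O`) gives 7100 nM

For the measured compounds named here, both values come from a functional assay on 8505C cells (Homo sapiens) for cytotoxicity, read by sulforhodamine B assay, with a stated time of 96 h (on this read-out higher numbers stand for an effect only at larger amounts of compound and lower numbers for an effect already at smaller amounts), and, with only two compounds measured, compound 2 holds the lower number at 7100 nM and so stands lowest so far.

The next compound to be measured is compound 3 (`CCCC(=O)CC/C=C/C=C/C#CC#C/C=C/C(=O)O`). Its difference from compound 2 lies in one place (hydroxy in place of hydrogen on a carbonyl carbon): hydroxy in place of hydrogen on a carbonyl carbon, which turns formyl into carboxy.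

Going by the values given here, only one measured step bears on this change, and it also involves the formyl group. It is a 2.7-fold lower number from compound 1 to compound 2 (0.43 log units; beyond the scatter) and counts as a modest step beyond the scatter. Among the compounds with values here, no measured compound carries carboxy, so this single step is thin evidence. Still, formyl sits on the lower of the two numbers, so losing it is expected to raise the number by a modest or somewhat larger amount. The estimated change is a 3.5-fold higher number from compound 2 to compound 3 (0.55 log units; beyond the scatter) in this assay, though its size is uncertain. For compound 3 the expected value is 25000 nM, with an estimated range from 8000 nM to 80000 nM.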

Compound 3, half-maximal effective concentration: 19300 nM
Beside the measured number, compound 3's estimate is 1.3-fold (0.11 log units) above it; low and high end bracket the measured number.
By their numbers in this assay, from the lowest: compound 2; then compounds 1 and 3 (each within the scatter of the next).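

In this assay, hydroxy in place of hydrogen on a carbonyl carbon, which turns formyl into carboxy, gives a 2.7-fold higher number from compound 2 to compound 3 (0.43 log units; beyond the scatter), so this position now has two measured changes involving formyl, and compound 2 carries the lower number in both. The carboxy group and the (((chloromethyl)carbonyl)oxy)methyl group cannot be told apart on this read-out, with no change at the digits printed from compound 1 to compound 3 (within the scatter), so among these three compounds only the formyl compound stands apart, with both of its steps beyond the scatter. Nothing available explains why formyl stands apart from the other two groups.

The compounds shown leave open whether formyl is unusual at this place or whether other groups on the double-bonded chain carbon, such as a methyl ester, an amide, a nitrile or a simple hydroxymethyl, would match it or give a still lower number. They also leave open whether the step from formyl to carboxy would keep its size if the ketone elsewhere on the chain were changed or if the chain were made shorter or longer.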